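The source may hold more compounds than are shown below. What is called first, only, known or untested is meant among the compounds shown, and "the series" means these compounds.

Three compounds share one core and differ only in the small group carried on their outer six-membered ring. In an assay on isolated protein for inhibition of Indoleamine 2,3-dioxygenase 1 (Homo sapiens), read by HPLC, with a stated time of 60 min, in the presence of a further agent that is not named here (on this read-out higher numbers stand for weaker inhibition and lower numbers for stronger inhibition), compound 1, with the structure `COc1cccc(Sc2c[nH]c3ccc(Cl)cc23)c1`, gives 21000 nM. Compound 2, with the structure `COc1ccc(Sc2c[nH]c3ccc(Cl)cc23)cc1`, gives 16000 nM in this assay, which is within the scatter of the value of compound 1; the two have the same atoms joined differently, and the difference between the two cores is not broken down here. Compound 3, with the structure `Cc1cccc(Sc2c[nH]c3ccc(Cl)cc23)c1`, gives 100000 nM in this assay.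

One change has been measured directly: methyl in place of methoxy on an aromatic carbon. It brought a 4.8-fold higher number from compound 1 to compound 3 (0.68 log units; beyond the scatter), so the swap of methoxy for methyl weakened inhibition.

Compound 4, with the structure `Cc1ccc(Sc2c[nH]c3ccc(Cl)cc23)cc1`, has not yet been measured. It differs from compound 2 by methyl in place of methoxy on an aromatic carbon. Within the data shown here, this is the same kind of change as the one from compound 1 to compound 3, but not the same: in compound 3 the methyl sits meta to a large group, while in compound 4 it sits para to a large group.

In this assay, among the measured compounds shown here, a step of about a 4.4-fold higher number from compound 2 to compound 4 (0.64 log units; beyond the scatter) is expected from compound 2 to compound 4, resting on the single measured example, the step of a 4.8-fold higher number from compound 1 to compound 3 (0.68 log units; beyond the scatter), and allowing for the different place. Compound 4 is therefore estimated at 70000 nM, most likely between 25000 nM and 200000 nM.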

Compound 4, half-maximal inhibitory concentration: > 200000 nM
Compound 4 ended at the assay's limit (the forecaster's own chance of this, stated with the estimate: 20%); middle value at least 2.8-fold (0.45 log units) from the limit.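

In this assay, methyl in place of methoxy on an aromatic carbon again weakened inhibition, giving an at least 12-fold higher number from compound 2 to compound 4 (1.09 log units; beyond the scatter), so the direction of the change carried over from the core of compound 1 to the core of compound 2. Among these compounds, the result for compound 4 is a limit of the assay and not a number, so it fixes only one end of this step: the limit of > 200000 nM in this assay, at which 1 of the 4 values shown sits. The two pairs therefore show that the swap weakened inhibition on both cores, but they do not show whether it costs the same amount on each, or whether the step is larger where the group sits para to a large group: the same change on two cores in this assay, a 4.8-fold higher number (0.68 log units; beyond the scatter) from compound 1 to compound 3 and an at least 12-fold higher number (1.09 log units; beyond the scatter) from compound 2 to compound 4; the limit leaves it open whether they differ.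

The compounds shown compare only methoxy and methyl, at two places on the outer ring, so two pairs are all that can be said about how this change travels through the series. As far as these compounds go, it remains open how an amine, a carboxylic acid or a longer chain such as ethoxy would read in this assay at these same places, and whether any of them would give stronger inhibition than methoxy does.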